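Swapping the thioether ring on a naphthol amide core

The source may report more compounds than this note shows. Statements on the series, on what has been measured and on what is new or still open speak of the compounds shown alone.

Measured in a functional assay on PC-3 cells (Homo sapiens) for antiproliferative activity, read by MTT assay, with a stated time of 48 h; a higher number here means a weaker inhibitor, a lower number a stronger inhibitor:
Compound 1 `O=C(Nc1cc(Sc2ncn[nH]2)c(O)c2ccccc12)c1cccc([N+](=O)[O-])c1` gives 26900 nM.
Compound 2 `Cc1nnc(Sc2cc(NC(=O)c3ccc(Cl)cc3)c3ccccc3c2O)s1` gives 49500 nM.
Compound 3 `O=C(Nc1cc(Sc2ncn[nH]2)c(O)c2ccccc12)c1ccc2ccccc2c1` gives only a limit of the assay, > 100000 nM.

Of the two actual numbers, compound 2 and compound 1 lie within the usual scatter of each other, so neither can be called weaker or stronger. For the measured compounds named here, the one measured step, an at least 3.7-fold higher number from compound 1 to compound 3 (0.57 log units; beyond the scatter), changes the group on the carbonyl carbon, and at its end compound 3 sits at the limit (the limit of > 100000 nM in this assay, at which 1 of the 3 values shown sits).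

Compound 4 `O=C(Nc1cc(Sc2ncnc3nc[nH]c23)c(O)c2ccccc12)c1ccc(Cl)cc1` differs from compound 2 elsewhere: a group of 9 heavy atoms (5 carbon, 4 nitrogen; one five-membered aromatic ring with 2 hetero atoms, one six-membered aromatic ring with 2 hetero atoms) in place of a group of 6 heavy atoms (3 carbon, 2 nitrogen, 1 sulfur; one five-membered aromatic ring with 3 hetero atoms), on a sulfur. Going by the values given here, no measured step touches this sulfur-linked group, so the step from compound 1 to compound 3 gives no guidance on its direction. With nothing in the data pointing either way, the expected step in this assay is a 1.1-fold lower number from compound 2 to compound 4 (0.04 log units; within the scatter), that is, none beyond the scatter. Compound 4 is therefore estimated at 45000 nM, in a range from 15000 nM to 130000 nM.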

Compound 4, half-maximal inhibitory concentration: 66400 nM
For compound 4 the middle estimate is 1.5-fold (0.17 log units) below the measured one; the range from low to high includes it.
By their numbers in this assay, from the lowest: compounds 1, 2 and 4 (each within the scatter of the next, the first and the last beyond it). At a limit, above all of these: compound 3.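

In this assay, for the compounds shown here, the first measured step at this sulfur is a 1.3-fold higher number from compound 2 to compound 4 (0.13 log units; within the scatter). The 5-methyl-1,3,4-thiadiazol-2-yl group and the group that enters in compound 4, with its five-membered and six-membered aromatic rings and one hydrogen-bond donor, therefore give numbers that cannot be told apart. So a considerable difference in the sulfur-linked group, on an aromatic carbon's sulfur in the shared core, has no visible effect in this single pair, whereas the one earlier step concerned the carbonyl side. Nothing shown explains why the two numbers agree.

As far as these compounds go, it remains open whether this holds when the group on the carbonyl carbon is different. From the compounds shown here alone, it is also open what a non-aromatic group on this sulfur, such as a butyl chain or one ending in a carboxylic acid, would give.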